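The source may hold more compounds than are shown below. What is called first, only, known or untested is meant among the compounds shown, and "the series" means these compounds.

Measured so far:
compound 1 `Cc1c(C(=O)Nc2ccc(Oc3ncnc4[nH]cc(-c5ccccc5)c34)c(F)c2)c(=O)c2ccccc2n1C` — in an assay on isolated protein for inhibition of tyrosine-protein kinase receptor UFO (Homo sapiens), read by FRET and Z'-LYTE, with a stated time of 1.5 h (on this read-out higher numbers stand for weaker inhibition and lower numbers for stronger inhibition), compound 1 gives > 10000 nM, a limit of the assay and not a number.
compound 2 `Cc1c(C(=O)Nc2ccc(Oc3ncnc4[nH]cc(-c5ccccc5)c34)c(F)c2)c(=O)c2c(Cl)cccc2n1C` — in this assay compound 2 gives > 10000 nM, likewise a limit of the assay.

For the measured compounds named here, compound 1 therefore stands only at a limit, and the one further value shown is a limit as well; both sit at the limit of > 10000 nM in this assay, at which 2 of the 2 values shown sit. Going by the values given here, the single step between measured compounds, a step that the two limits leave unreadable from compound 1 to compound 2, chloro in place of hydrogen on an aromatic carbon, is left unreadable by the two limits.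

Compound 3 `CCCc1ccc2c(c1)c(=O)c(C(=O)Nc1ccc(Oc3ncnc4[nH]cc(-c5ccccc5)c34)c(F)c1)c(C)n2C` differs from compound 1 by propyl in place of hydrogen on an aromatic carbon. Among the compounds with values here, no measured step bears on this change: the only step on record cannot be read, and compound 1 itself has no number in this assay. Nothing in the data points to a move beyond the scatter in either direction. Compound 3 is estimated at 15000 nM, in the range 3000 nM to 60000 nM, most likely again reported as a limit; the expected step is a step that the limit leaves unreadable from compound 1 to compound 3.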

Compound 3, half-maximal inhibitory concentration: 61 nM
Estimate against measurement, compound 3: 250-fold (2.39 log units) above; the measured number lies below the stated range.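

Propyl in place of hydrogen on this aromatic carbon, meta to a fused ring and para to a fused ring, gives an at least 160-fold lower number from compound 1 to compound 3 (2.21 log units; beyond the scatter) in this assay. This shows that a single small chain at this place on the core of compound 1 can move the read-out far beyond the scatter, which the chloro change could not show, since that step cannot be read with both of its ends at limits. The series now holds one real number, while the other values remain limits: the limit of > 10000 nM in this assay, at which 2 of the 3 values shown sit.

As far as these compounds go, it remains open whether a shorter chain such as methyl, a longer chain such as butyl, or an amine or a carboxylic acid on the same aromatic carbon would give a comparable number. From the compounds shown here alone, the full size of the step also stays open, as compound 1 has only a limit.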